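Methoxy for methyl on two thiazolo-fused cores

The source may report more compounds than this note shows. Statements on the series, on what has been measured and on what is new or still open speak of the compounds shown alone.

Measured compounds:
compound 1 `Cc1ccc(-c2c(CN3CCCCC3)nc3scc(C(=O)O)n23)cc1` with 10800 nM
compound 2 `COc1ccc(-c2c(CN3CCCCC3)nc3scc(C(=O)O)n23)cc1` with 75100 nM
compound 3 `CC(=O)NNC(=O)c1csc2ncc(-c3ccc(C)cc3)n12` with 63600 nM

In a functional assay on HepG2 cells (Homo sapiens) for antiproliferative activity, read by MTT assay, with a stated time of 72 h (a higher number here means a weaker inhibitor, a lower number a stronger inhibitor), compound 1 gives 10800 nM, while compound 2 gives 75100 nM. The change between them, (methoxy in place of methyl on an aromatic carbon), gave a 7.0-fold higher number from compound 1 to compound 2 (0.84 log units; beyond the scatter). Compound 3 belongs to a different core, and the difference between the two cores is not broken down here; in this assay compound 3 gives 63600 nM, which lies near the value of compound 2 and well away from that of compound 1.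

Compound 4 `COc1ccc(-c2cnc3scc(C(=O)NNC(C)=O)n23)cc1` has not yet been measured. It differs from compound 3 by methoxy in place of methyl on an aromatic carbon, the same change that turned compound 1 into compound 2, at the same kind of position. Because a 7.0-fold higher number from compound 1 to compound 2 (0.84 log units; beyond the scatter) weakened the first core, a step of similar direction is expected on the second core, with the expected step of a 4.7-fold higher number from compound 3 to compound 4 (0.67 log units; beyond the scatter). Since compound 3 already stands high, the number for compound 4 may reach the upper edge of what can be reported. The estimate for compound 4 in this assay is 300000 nM, with a range from 80000 nM to 1000000 nM.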

Compound 4, half-maximal inhibitory concentration: 11800 nM
For compound 4 the middle estimate is 25-fold (1.41 log units) above the measured one; the whole stated range lies above it.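

In this assay, replacing methyl with methoxy on the six-membered aromatic ring gave a 5.4-fold lower number from compound 3 to compound 4 (0.73 log units; beyond the scatter), which runs opposite to the step seen on the other core, and the two steps differ clearly: the same change on two cores in this assay, a 7.0-fold higher number (0.84 log units; beyond the scatter) from compound 1 to compound 2 and a 5.4-fold lower number (0.73 log units; beyond the scatter) from compound 3 to compound 4, 37-fold (1.57 log units) apart, beyond the scatter of two such steps

For these four compounds, then, the direction of the change on one core did not carry over to the other, so the step from the first pair would have been a poor guide to the second. Within the data shown here, this does not show which structural difference goes with the reversal, and with only one pair on each core it sets no rule for the wider series.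

The compounds shown leave open whether the reversal follows the piperidinylmethyl group, present only in compound 1 and compound 2, or the carboxylic acid in those compounds as against the acetyl hydrazide in compound 3 and compound 4, as these differences occur together here. They also leave open how an ethoxy group or a chlorine atom in the same place would behave on each core.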